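This account rests on a few compounds, and the source may have more. Where it says the series, first, only, none or still open, it means among the compounds named here.

Compounds measured so far:
compound 1, `Nc1nn(C(=O)Nc2ccc(Cc3ccccc3)cc2)c2ccccc12`, > 100000 nM
compound 2, `Nc1nn(C(=O)Nc2ccc(Cc3ccccc3)cc2)c2ccc(Cl)cc12`, 25100 nM

In a functional assay on HCT-116 cells (Homo sapiens) for antiproliferative activity, read by sulforhodamine B assay, with a stated time of 48 h (on this read-out lower numbers stand for stronger inhibition of growth and higher numbers for weaker inhibition of growth), compound 1 gives only a limit, > 100000 nM. Where compound 1 has hydrogen, compound 2 carries a chloro, and in this assay compound 2 gives 25100 nM. Within the data shown here, compound 2 is thus the only compound with a proper number; the other value is a limit (the limit of > 100000 nM in this assay, at which 1 of the 2 values shown sits). Among the measured compounds shown here, the single measured step, an at least 3.9-fold lower number from compound 1 to compound 2 (0.60 log units; beyond the scatter), goes toward stronger growth inhibition.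

Compound 3, `Nc1ccc2c(c1)c(N)nn2C(=O)Nc1ccc(Cc2ccccc2)cc1`, differs from compound 2 by amino in place of chloro on an aromatic carbon. For the measured compounds named here, no measured step exchanges one group for another at this carbon, so the step from compound 1 to compound 2 bears on it only loosely. Compound 3 is therefore expected to give 35000 nM in this assay, with a range from 10000 nM to 120000 nM. This corresponds to an expected 1.4-fold higher number from compound 2 to compound 3 (0.14 log units; within the scatter), not beyond the scatter.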

Compound 3, concentration for total growth inhibition: 20800 nM
The estimate for compound 3 lay 1.7-fold (0.23 log units) above the measured number; the range from low to high includes it.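

The exchange of amino for chloro on this aromatic carbon gives a 1.2-fold lower number from compound 2 to compound 3 (0.08 log units; within the scatter) in this assay and so does not separate the two groups, although amino carries a hydrogen-bond donor and a hydrogen-bond acceptor and chloro carries neither. Amino in place of hydrogen gives an at least 4.8-fold lower number from compound 1 to compound 3 (0.68 log units; beyond the scatter) and so shows that the gain over hydrogen at this carbon is not tied to chloro alone. The value of compound 1 is a limit, and the size of both steps from it is to be read with that in mind: the limit of > 100000 nM in this assay, at which 1 of the 3 values shown sits.

On these data alone, it remains open whether other groups on this carbon, such as a methoxy group, a carboxylic acid or a longer chain, would match amino and chloro or differ from them. As far as these compounds go, it also remains open whether the same holds on the other carbons of this six-membered ring.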